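From compound 2 to compound 3: a sulfonyl sulfur swap

The source may hold more compounds than are shown below. What is called first, only, known or untested is meant among the compounds shown, and "the series" means these compounds.

Compound 1 `O=C(NCc1ccc(S(=O)(=O)C2CCOCC2)cc1)N1Cc2ccncc2C1`: 6 mL/min/kg
Compound 2 `CC(=O)N1CCC(S(=O)(=O)c2ccc(CNC(=O)N3Cc4ccncc4C3)cc2)CC1`: 6 mL/min/kg

In an ADME assay on microsomes from liver (Homo sapiens) for pharmacokinetics, read by LC-MS, with a stated time of 60 min, tested at 1 uM (a higher number here means faster removal of the compound, a lower number slower removal), compound 2 stands at 6 mL/min/kg, level with compound 1 at 6 mL/min/kg. Compound 3 `O=C(NCc1ccc(S(=O)(=O)N2CC3(CCOCC3)C2)cc1)N1Cc2ccncc2C1` has not yet been measured. Its difference from compound 2 is a group of 9 heavy atoms (7 carbon, 1 nitrogen, 1 oxygen; one four-membered non-aromatic ring with 1 hetero atom, one six-membered non-aromatic ring with 1 hetero atom) in place of a group of 9 heavy atoms (7 carbon, 1 nitrogen, 1 oxygen; one six-membered non-aromatic ring with 1 hetero atom), on a sulfonyl sulfur; the two have the same atoms, joined differently.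

Within the data shown here, only one measured step bears on this change, also made on a sulfonyl sulfur: no change at the digits printed from compound 1 to compound 2 (within the scatter). That step lies within the scatter. It offers only limited guidance, since neither measured compound carries a four-membered ring. The data therefore give no direction for a shift in this assay. The expected change is a 1.2-fold higher number from compound 2 to compound 3 (0.07 log units; within the scatter), which would be no step beyond the scatter. Compound 3 is estimated at 7 mL/min/kg, with an expected range of 4 mL/min/kg to 14 mL/min/kg.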

Compound 3, clearance: 13 mL/min/kg
Compound 3: the middle estimate sits 1.9-fold (0.27 log units) below what was measured, and the stated range covers the measured number.
By their numbers in this assay, from the lowest: compounds 1 and 2 (each within the scatter of the next); then compound 3.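

The sulfonyl sulfur, where 1-acetylpiperidin-4-yl and oxan-4-yl could not be told apart in this assay, now proves able to register a change of group: with the same atoms joined differently, the new group gives a 2.2-fold higher number from compound 2 to compound 3 (0.34 log units; beyond the scatter). Against the smaller oxan-4-yl group the result is a 2.2-fold higher number from compound 1 to compound 3 (0.34 log units; beyond the scatter), so the modest move towards faster removal appears against both earlier groups, and only compound 3 carries a four-membered ring. Nothing measured here accounts for this shift.

The compounds shown leave open whether the four-membered ring alone goes with the higher number, or whether it depends on the whole group with its six-membered ring. A plain azetidine or a morpholine on the same sulfonyl sulfur would separate those readings.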